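The compounds below may be only part of what the source reports. "The series", "measured", "known", "first", "only" and "open" are said of these compounds alone.

Series notes. Of the compounds shown here, three built on the shared core have been measured in an assay on COS-7 cells for inhibition of Fatty-acid amide hydrolase 1 (Homo sapiens), read by scintillation counting, with a stated time of 10 min, tested at 10 uM; on this read-out lower numbers stand for less inhibition and higher numbers for more inhibition at the one concentration tested (going by the name of the read-out). Compound 1 `COc1nn(Cc2ccccc2[N+](=O)[O-])c(=O)o1` gives 36% in this assay and carries the only figure in the set. Compound 2 `COc1nn(Cc2cccc(NC(C)=O)c2)c(=O)o1` is reported in this assay as "not active" (no number reported), with no number beside it. Compound 3 `COc1nn(Cc2cccc(NC(=O)c3ccccc3)c2)c(=O)o1` is reported in this assay as "not active" (no number reported), again without a number. On the numbers shown, compound 2 therefore stands among the entries without a single value, and nothing places it above or below compound 3.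

Compound 4 `COc1nn(Cc2cccc(Cl)c2)c(=O)o1` has not yet been measured in this assay. The change from compound 2 to compound 4 is chloro in place of acetamido on an aromatic carbon. Among the compounds with values here, no step between two measured compounds is recorded, so the size of this move in this assay has no measured precedent, and the direction cannot be read from the set. The expectation is a step of no more than the scatter, in either direction, because compound 2 stands at "not active" (no number reported) and offers no number to move from. For compound 4 the expected inhibition in this assay is 15%, estimated within a range from 0% to 40%.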

Compound 4, a percentage reported as inhibition, at one concentration (the size of the read-out at that concentration, not a potency): 37%
Estimate against measurement, compound 4: 22 percentage points below; measured number inside the range.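

In this assay, within the data shown here, compound 4 gives 37%, but compound 2 has no number to compare with, so no step between compound 2 and compound 4 can be read. The compounds shown leave open how far chloro in place of acetamido shifts inhibition on this read-out. No evidence on this result is available.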